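Fluoro for Acetyl on an Aryl Urea: Expected Read-out

The source may report more compounds than this note shows. Statements on the series, on what has been measured and on what is new or still open speak of the compounds shown alone.

Measured compounds:
compound 1, `COc1ccccc1NC(=O)N[C@@H](C)c1ccccc1`, 99%
compound 2, `CC(=O)c1ccccc1NC(=O)N[C@@H](C)c1ccccc1`, 97%

In an ADME assay on the whole organism with Oryza sativa as the target, tested at 1 uM (on this read-out higher numbers stand for a weaker effect at the one concentration tested and lower numbers for a stronger effect), compound 2 stands at the lowest of the two numbers, with compound 1 nearest; the step of a number 2 percentage points lower from compound 1 to compound 2 (within the scatter) lies within the scatter. Compound 3, `C[C@H](NC(=O)Nc1ccccc1F)c1ccccc1`, differs from compound 2 by fluoro in place of acetyl on an aromatic carbon. Among the measured compounds shown here, the only measured step that bears on this change is a number 2 percentage points lower from compound 1 to compound 2 (within the scatter), a swap at the same aromatic carbon, and it was small. Compound 3 is therefore expected to show no step beyond the scatter, no change at the digits printed from compound 2 to compound 3 (within the scatter), and its estimated value is 97%, between 88% and 100%.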

Compound 3, a percentage reported as activity, at one concentration (the size of the read-out at that concentration, not a potency): 92%
Beside the measured number, compound 3's estimate is 5 percentage points above it, and the stated range covers the measured number.
By their numbers in this assay, from the lowest: compounds 3, 2 and 1 (each within the scatter of the next).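

In this assay, fluoro in place of acetyl on an aromatic carbon gives a number 5 percentage points lower from compound 2 to compound 3 (within the scatter) and fluoro in place of methoxy gives a number 7 percentage points lower from compound 1 to compound 3 (within the scatter). At this place, ortho to a large group, a fluoro with 1 heavy atom and 0 hydrogen-bond acceptors thus stands within the scatter of both acetyl, with 3 heavy atoms and 1 hydrogen-bond acceptor, and methoxy. Nothing at hand speaks to the cause of this result. On these data alone, whether an amine or a carboxylic acid on this aromatic carbon would stay within the scatter remains open, as does whether any group here would step beyond it.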